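The compounds below may be only part of what the source reports. "The series", "measured", "known", "first", "only" and "open" are said of these compounds alone.

The three measured compounds and their values:

- compound 1, `Oc1cc(C(F)(F)F)ccc1-c1nc(-c2ccccc2O)n(-c2ccc(I)cc2)n1`, gives 70.1%
- compound 2, `Oc1cc(C(F)(F)F)ccc1-c1nc(-c2ccccc2O)n(-c2ccccc2F)n1`, gives 63.4%
- compound 3, `COc1cccc(-n2nc(-c3ccc(C(F)(F)F)cc3O)nc2-c2ccccc2O)c1`, gives 68.3%

These numbers come from a functional assay on PC-12 cells (Rattus norvegicus) for cytotoxicity, read by MTT assay, with stated times of 2 h and 24 h, tested at 1 uM; a lower number here means a weaker effect, a higher number a stronger effect of the compound at the concentration tested. All three compounds share the same core and differ only in the group carried on an aromatic nitrogen of that core. On these numbers compound 3 stands second highest of the three. Its nearest neighbour is one step away, a number 1.8 percentage points lower from compound 1 to compound 3 (within the scatter), and its furthest is a number 4.9 percentage points higher from compound 2 to compound 3 (within the scatter); both of these lie within the scatter, so the three values cannot be told apart with confidence.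

Compound 4, `Cc1cc(C)cc(-n2nc(-c3ccc(C(F)(F)F)cc3O)nc2-c2ccccc2O)c1`, is the next compound to be tested. Relative to compound 3 the change is 3,5-dimethylphenyl in place of 3-methoxyphenyl on an aromatic nitrogen.

Every step measured so far swaps exactly this group on the aromatic nitrogen: a number 6.7 percentage points lower from compound 1 to compound 2 (within the scatter), a number 1.8 percentage points lower from compound 1 to compound 3 (within the scatter) and a number 4.9 percentage points higher from compound 2 to compound 3 (within the scatter). None of them moved the read-out beyond the scatter. The same kind of exchange is now made once more, so the expected step is no step beyond the scatter, estimated as a number 1.3 percentage points lower from compound 3 to compound 4 (within the scatter). For compound 4 the estimate in this assay is therefore 67%, with a range from 57% to 77%.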

Compound 4, a percentage reported as activity, at one concentration (the size of the read-out at that concentration, not a potency): 76.9%
Estimate against measurement, compound 4: 9.9 percentage points below, and the stated range covers the measured number.
By their numbers in this assay, from the lowest: compounds 2, 3, 1 and 4 (each within the scatter of the next, the first and the last beyond it).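

In this assay, for the compounds shown here, the group on the aromatic nitrogen now gives the first step beyond the scatter, a modest one: a number 13.5 percentage points higher from compound 2 to compound 4 (beyond the scatter), with 3,5-dimethylphenyl in place of 2-fluorophenyl, so this position can move the read-out by more than repeat measurements would. The other two steps, a number 8.6 percentage points higher from compound 3 to compound 4 (within the scatter) and a number 6.8 percentage points higher from compound 1 to compound 4 (within the scatter), stay within the scatter, so compound 4 cannot be told apart from compound 3 or compound 1, and only compound 2 and compound 4 are separated. No measurement at hand explains the step from 2-fluorophenyl to 3,5-dimethylphenyl.

Going by these compounds, all four groups at this position are substituted phenyl rings, so it remains open what a phenyl ring carrying an amine or a carboxylic acid, or a plain alkyl chain in place of the ring, would do to the read-out. On these data alone, each value also describes the size of the effect at one concentration rather than a potency, so it remains open whether the separation of compound 2 and compound 4 would hold at other concentrations.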